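Aryl variation on the piperazine nitrogen: toward compound 4

The source may report more compounds than this note shows. Statements on the series, on what has been measured and on what is new or still open speak of the compounds shown alone.

Measured so far:
compound 1, `Nc1scc(CN2CCN(c3ccc(Cl)cc3F)CC2)c1C(=O)c1ccc(Cl)cc1`, -57%
compound 2, `Nc1scc(CN2CCN(c3ccc([N+](=O)[O-])cc3)CC2)c1C(=O)c1ccc(Cl)cc1`, -8.3%
compound 3, `Nc1scc(CN2CCN(c3cccc(Cl)c3)CC2)c1C(=O)c1ccc(Cl)cc1`, -59%

In a functional assay on CHO cells with adenosine receptor A1 (Homo sapiens) as the target, read by cAMP accumulation and immunoassay, with a stated time of 6 min, tested at 1 uM (a higher number here means a weaker effect of the compound at the concentration tested, a lower number a stronger effect), compound 1 stands second highest of the three numbers. Its nearest neighbour is compound 3, reached by the step of a number 2 percentage points lower from compound 1 to compound 3 (within the scatter); its furthest is compound 2, reached by the step of a number 48.7 percentage points higher from compound 1 to compound 2 (beyond the scatter). Compound 4 is `Nc1scc(CN2CCN(c3ccccc3Cl)CC2)c1C(=O)c1ccc(Cl)cc1`; relative to compound 1 the change is 2-chlorophenyl in place of 4-chloro-2-fluorophenyl on an amine nitrogen in a ring.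

Among the measured compounds shown here, two measured steps bear on this change. The step of a number 2 percentage points lower from compound 1 to compound 3 (within the scatter) shows that a chlorophenyl without the fluorine gives a number within the scatter of compound 1. The steps of a number 48.7 percentage points higher from compound 1 to compound 2 (beyond the scatter) and a number 50.7 percentage points lower from compound 2 to compound 3 (beyond the scatter) show that only the nitro-bearing phenyl of compound 2 moves the number far, and in the direction of a weaker effect. Compound 4 keeps a chlorophenyl and carries no nitro group, so no step beyond the scatter is expected from compound 1; the expected step is a number 7 percentage points higher from compound 1 to compound 4 (within the scatter). Compound 4 is accordingly estimated at -50%, with a range from -70% to -25%. The single shift of the chlorine within the phenyl, with three measured compounds only, leaves the range wide.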

Compound 4, a percentage reported as activity, at one concentration (the size of the read-out at that concentration, not a potency): -5.2%
Estimate against measurement, compound 4: 44.8 percentage points below, outside the stated range (above it).
By their numbers in this assay, from the lowest: compounds 3 and 1 (each within the scatter of the next); then compounds 2 and 4 (each within the scatter of the next).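

In this assay, moving the chlorine changes the outcome: a number 53.8 percentage points higher from compound 3 to compound 4 (beyond the scatter) separates the 2-chlorophenyl group from the 3-chlorophenyl group, so a chlorophenyl on this amine nitrogen in a ring does not by itself preserve the stronger effect. The 2-chlorophenyl group also parts from the 4-chloro-2-fluorophenyl group, with a number 51.8 percentage points higher from compound 1 to compound 4 (beyond the scatter), while a number 3.1 percentage points higher from compound 2 to compound 4 (within the scatter) places it with the 4-nitrophenyl group, so a nitro group is not needed for a number at this weaker level. No measurement at hand accounts for these differences.

The compounds shown do not separate the effect of chlorine placement from that of the fluorine and chlorine combination in compound 1, and a plain phenyl or a fluorophenyl without chlorine would bear directly on that question. A methoxyphenyl or a methylphenyl on the same nitrogen would show whether the sharp change in this assay is specific to chlorine or extends to other groups on the phenyl ring.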